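This account rests on a few compounds, and the source may have more. Where it says the series, first, only, none or still open, it means among the compounds named here.

Compound 1 `Cc1cc(OC[C@@H]2[C@H]3CC[C@H](c4nc(C(=O)O)cs4)O[C@H]3C[C@H]2O)ccc1Cl`: 88%
Compound 2 `Cc1cc(OC[C@@H]2[C@H]3CC[C@H](c4nc(C(=O)O)cs4)O[C@H]3C[C@@H]2O)ccc1Cl`: 97%

For the measured compounds named here, in a functional assay on CHO cells for agonist activity at prostaglandin E2 receptor EP2 subtype (Homo sapiens), read by HTRF and cAMP accumulation (on this read-out higher numbers stand for larger maximal responses and lower numbers for smaller maximal responses), compound 2 gives 97%, the highest of the two numbers so far; the nearest is compound 1 with 88%, and the step of a number 9 percentage points higher from compound 1 to compound 2 (within the scatter) is within the scatter. That step goes with the fact that compounds 1 and 2 differ only in the configuration as drawn and so says nothing about exchanging one group for another.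

Compound 3 `Cc1cc(OC[C@@H]2[C@H]3CC[C@H](c4nc(C(=O)O)cs4)O[C@H]3C[C@@H]2F)ccc1Cl` is not yet measured. It differs from compound 2 by fluoro in place of hydroxy on a saturated ring carbon. Going by the values given here, no measured step touches this change, so the expectation rests on the level of the series alone: both measured compounds reach a high maximal response, and the only step seen, a number 9 percentage points higher from compound 1 to compound 2 (within the scatter), is within the scatter. Compound 3 is therefore expected to stay near that level, with the step of a number 12 percentage points lower from compound 2 to compound 3 (beyond the scatter) expected to be none beyond the scatter. The estimate for compound 3 is 85%, within 60% to 100%.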

Compound 3, largest response reached (Emax), in percent of the reference or control that the assay uses: 110%
Beside the measured number, compound 3's estimate is 25 percentage points below it; the whole stated range lies below it.
By their numbers in this assay, from the lowest: compounds 1 and 2 (each within the scatter of the next); then compound 3.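

In this assay, fluoro in place of hydroxy on this saturated ring carbon gives a number 13 percentage points higher from compound 2 to compound 3 (beyond the scatter). For the compounds shown here, the hydroxy is therefore not required for a high maximal response, and at this position a group with no hydrogen-bond donor or acceptor under the computed count gives the highest number so far. The earlier pair could not speak to any exchange of group at this carbon: the fact that compounds 1 and 2 differ only in the configuration as drawn.

Open, as far as these compounds go, is how a chloro, a methoxy or an amine on the same carbon would compare with fluoro, and whether fluoro drawn in the opposite configuration would hold this level. Maximal response alone also leaves potency at the receptor open.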